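The source may hold more compounds than are shown below. What is called first, only, known or untested is meant among the compounds shown, and "the series" means these compounds.

The measured compounds in a functional assay on HepG2 cells (Homo sapiens) for antiproliferative activity, read by MTT assay, with a stated time of 48 h; on this read-out lower numbers stand for stronger inhibition and higher numbers for weaker inhibition:
- compound 1 `N#CC1=C(N)Oc2c(c3nc4ccccc4nc3c3ccccc23)C12C(=O)N(Cc1cnnn1-c1ccc(S(N)(=O)=O)cc1)c1ccccc12` gives 42200 nM.
- compound 2 `N#CC1=C(N)Oc2c(c3nc4ccccc4nc3c3ccccc23)C12C(=O)N(Cc1cnnn1-c1ccc(Cl)c(Cl)c1)c1ccccc12` reaches only the limit > 50000 nM, not a number.
- compound 3 `N#CC1=C(N)Oc2c(N)cc3nc4ccccc4nc3c2C12C(=O)N(Cc1cnnn1-c1ccccc1Br)c1ccccc12` gives 38000 nM.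

Compound 3 holds the lowest of the two numbers, and compound 1 sits within the scatter of it. Compound 4 `Cc1cc(C)c(-n2nncc2CN2C(=O)C3(C(C#N)=C(N)Oc4c(N)cc5nc6ccccc6nc5c43)c3ccccc32)c(C)c1` differs from compound 3 in one place: 2,4,6-trimethylphenyl in place of 2-bromophenyl on an aromatic nitrogen. One measured step swaps the aryl group on the same aromatic nitrogen: an at least 1.1-fold higher number from compound 1 to compound 2 (0.07 log units; that floor lies within the scatter). That step stays within the scatter, and its floor rests on a limit (the limit of > 50000 nM in this assay, at which 1 of the 3 values shown sits), so it cannot show how far a swap at this place moves the number. No step beyond the scatter is therefore expected in this assay; the estimated step is a 1.1-fold higher number from compound 3 to compound 4 (0.02 log units; within the scatter). Compound 4 is expected to give 40000 nM, between 15000 nM and 50000 nM.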

Compound 4, half-maximal inhibitory concentration: 48100 nM
The estimate for compound 4 lay 1.2-fold (0.08 log units) below the measured number; measured number inside the range.
By their numbers in this assay, from the lowest: compounds 3, 1 and 4 (each within the scatter of the next). At a limit, above all of these: compound 2.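

In this assay, the swap on this aromatic nitrogen can now be read between two real numbers, not against a limit: a 1.3-fold higher number from compound 3 to compound 4 (0.10 log units; within the scatter). So 2-bromophenyl and 2,4,6-trimethylphenyl cannot be told apart here, even though the entering group has no bromine and more carbon. Compound 2 still stands at a limit, not a number: the limit of > 50000 nM in this assay, at which 1 of the 4 values shown sits.

The compounds shown leave open whether any group at this place moves the number beyond the scatter. A phenyl ring carrying an amine or a carboxylic acid, or a plain alkyl chain, could test that.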